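A few compounds are considered here, and "the series" means these few. Any claim that something is new, unique, unknown or untested is made for them only; others in the source may bear on it.

Measured compounds:
compound 1 `C#CCOc1ccc(/C=C/C(=O)c2ccc(OC)cc2)cc1`: 32%
compound 2 `O=C(/C=C/c1ccc(OCc2cn(Cc3ccccc3)nn2)cc1)c1ccc(Br)cc1`: 44%

In a functional assay on MIA PaCa-2 cells (Homo sapiens) for inhibition, read by MTT assay, with a stated time of 48 h, tested at 10 uM (on this read-out lower numbers stand for less inhibition of growth and higher numbers for more inhibition of growth at the one concentration tested), compound 2 gives 44%, the highest of the two numbers; the nearest, compound 1, lies lower by more than the usual scatter. Compound 3 `O=C(/C=C/c1ccc(OCc2cn(Cc3ccccc3Br)nn2)cc1)c1ccc(Br)cc1` differs from compound 2 by bromo in place of hydrogen on an aromatic carbon, on the benzyl attached to the triazole. For the measured compounds named here, no pair of measured compounds shows what such a change does here, so only a modest shift is expected, probably within the scatter, with a slight lean upward: a number 4 percentage points higher from compound 2 to compound 3 (within the scatter). Compound 3 is therefore estimated at 48%, with a range from 30% to 66%.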

Compound 3, percent growth inhibition at one concentration: 43%
Compound 3: middle estimate off by 5 percentage points, on the high side; low and high end bracket the measured number.
By their numbers in this assay, from the lowest: compound 1; then compounds 3 and 2 (each within the scatter of the next).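

In this assay, replacing benzyl with 2-bromobenzyl gives a number 1 percentage points lower from compound 2 to compound 3 (within the scatter). For the compounds shown here, a bromo group ortho to a large group on this benzyl therefore leaves the growth inhibition indistinguishable from that of the unsubstituted benzyl, which the earlier compounds could not show. No available evidence explains this result.

From the compounds shown here alone, whether an amine or a carboxylic acid at this position would also leave the number within the scatter remains open. So does the outcome of placing bromo on another carbon of the benzyl.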